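A Cinnamyl Ether in Place of a Succinate Half-Ester

This account rests on a few compounds, and the source may have more. Where it says the series, first, only, none or still open, it means among the compounds named here.

Among the measured compounds shown here, compound 1 `Cc1c(C)c2c(c(C)c1OC(=O)CCC(=O)O)CCC(C)(COc1ccc(/C=C3\SC(=O)NC3=O)cc1)O2` was tested in a functional assay on MCF7 cells (Homo sapiens), tested at 2.5 uM (on this read-out higher numbers stand for a weaker effect at the one concentration tested and lower numbers for a stronger effect), and gave 115%, the highest of the two numbers so far recorded. Compound 2 `COc1cc(/C=C2\SC(=O)NC2=O)ccc1OCC1(C)CCc2c(C)c(OCC=C(C)C)c(C)c(C)c2O1` gave 95% in this assay, a number lower than that of compound 1 by more than the usual scatter. Compound 3 `Cc1c(C)c2c(c(C)c1OC/C=C/c1ccccc1)CCC(C)(COc1ccc(/C=C3\SC(=O)NC3=O)cc1)O2` has not yet been measured. It differs from compound 1 in one place: 3-phenylprop-2-en-1-yl in place of (2-carboxyethyl)carbonyl on an oxygen on an aromatic ring. For the measured compounds named here, no step between measured compounds covers this change, so its effect in this assay can only be anticipated. Since compound 2, which likewise carries an ether on that oxygen, gave 95%, the step is expected to be a number 20 percentage points lower from compound 1 to compound 3 (beyond the scatter), a lowering somewhat beyond the scatter. Compound 3 is accordingly estimated at 95%, within a range from 75% to 115%.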

Compound 3, a percentage reported as activity, at one concentration (the size of the read-out at that concentration, not a potency): 92%
The estimate for compound 3 lay 3 percentage points above the measured number; measured number inside the range.
By their numbers in this assay, from the lowest: compounds 3 and 2 (each within the scatter of the next); then compound 1.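

In this assay, among the compounds shown here, this is the first step read directly at this position: 3-phenylprop-2-en-1-yl in place of (2-carboxyethyl)carbonyl on an oxygen on an aromatic ring gives a number 23 percentage points lower from compound 1 to compound 3 (beyond the scatter), a modest change toward a stronger effect. The entering group has no hydrogen-bond donors or acceptors, so the lower number does not require the donor and acceptors of the group that leaves. Nothing at hand bears on why the number moved.

On these data alone, it remains open whether the phenyl ring or the chain's double bond carries the step, and how a benzyl ether, a saturated 3-phenylpropyl chain or an amine-bearing chain on the same oxygen would read in this assay. Readings at a single concentration also leave open whether the step would hold for potency.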